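Sulfonamide amine exchange in a chloro-aryloxyacetic acid series

A few compounds are considered here, and "the series" means these few. Any claim that something is new, unique, unknown or untested is made for them only; others in the source may bear on it.

Measured so far:
compound 1, `COCCN(C)S(=O)(=O)c1ccc(C)c(C#Cc2cc(Cl)ccc2OCC(=O)O)c1`, 4.1 nM
compound 2, `Cc1ncccc1C#Cc1cc(Cl)ccc1OCC(=O)O`, 143 nM
compound 3, `O=C(O)COc1ccc(Cl)cc1C#Cc1cc(CO)ccc1F`, 73 nM

In an assay on CHO cells for displacement of a labelled ligand from prostaglandin D2 receptor 2 (Homo sapiens), read by scintillation counting (on this read-out higher numbers stand for weaker inhibition and lower numbers for stronger inhibition), compound 1 gives the lowest number of the three, compound 3 sits well beyond the scatter above it, and compound 2 lies furthest away, again beyond the scatter. Compound 1 is therefore the strongest of the three measured compounds.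

Compound 4, `Cc1ccc(S(=O)(=O)NC(C)(C)C)cc1C#Cc1cc(Cl)ccc1OCC(=O)O`, has not yet been measured in this assay. It differs from compound 1 only at the sulfonyl sulfur: (tert-butyl)amino in place of (2-methoxyethyl)(methyl)amino on a sulfonyl sulfur. The shared core and the chloro-aryloxyacetic acid part are untouched; the change exchanges a hydrogen-bond acceptor for a hydrogen-bond donor while the heavy-atom count barely moves. Going by the values given here, no measured pair in this set isolates a change at this sulfonyl position, so there is no step to lean on. On the basis of compound 1 at 4.1 nM alone, a small step in either direction, within or near the scatter, is expected rather than a large loss.

The step of a 1.5-fold higher number from compound 1 to compound 4 (0.17 log units; within the scatter) is expected to stay within the usual scatter.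

Compound 4 is estimated at 6 nM, with a range of 2 nM to 20 nM.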

Compound 4, inhibition constant: 5 nM
Compound 4: middle estimate off by 1.2-fold (0.08 log units), on the high side; the range from low to high includes it.
By their numbers in this assay, from the lowest: compounds 1 and 4 (each within the scatter of the next); then compounds 3 and 2 (each within the scatter of the next).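

In this assay, going by these compounds alone, (tert-butyl)amino in place of (2-methoxyethyl)(methyl)amino on a sulfonyl sulfur gives a 1.2-fold higher number from compound 1 to compound 4 (0.09 log units; within the scatter), the first direct reading at this position. A hydrogen-bond acceptor leaves with the 2-methoxyethyl chain and a hydrogen-bond donor enters, yet the two compounds cannot be told apart on this read-out, so in this pair neither the acceptor nor the methyl on the sulfonamide nitrogen is needed to keep the number low. Nothing measured here accounts for this outcome.

On these data alone, it remains open whether this holds for an unsubstituted amino group or a ring amine such as morpholine on the same sulfonyl sulfur. As far as these compounds go, the effect of a carboxylic acid on the amine chain at this position also remains open.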